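Inhibition in mice after an aryl substituent swap

A few compounds are considered here, and "the series" means these few. Any claim that something is new, unique, unknown or untested is made for them only; others in the source may bear on it.

Compounds measured so far:
compound 1, `Cn1c(-c2ccc(-c3cncnc3)cc2)nnc1C1(c2ccc(Cl)cc2)CCC1`, 46%
compound 2, `Cc1noc(C)c1-c1ccc(-c2nnc(C3(c4ccc(Cl)cc4)CCC3)n2C)cc1`, 63%

In a functional assay on the whole organism (strain ICR) for inhibition, with Mus musculus as the target, read by scintillation counting, with a stated time of 4 h, at a dose of 10 mg/kg by the oral route (on this read-out lower numbers stand for less inhibition and higher numbers for more inhibition at the one dose given (going by the name of the read-out)), compound 2 stands highest of the two numbers shown; its nearest neighbour is compound 1, and the step of a number 17 percentage points higher from compound 1 to compound 2 (beyond the scatter) lies beyond the scatter. Compound 3, `Cn1c(-c2ccc(C(=O)NC(C)(C)C)cc2)nnc1C1(c2ccc(Cl)cc2)CCC1`, differs from compound 2 by (tert-butyl)carbamoyl in place of 3,5-dimethyl-1,2-oxazol-4-yl on an aromatic carbon. Among the measured compounds shown here, no measured step bears directly on this change: the one step recorded exchanges one aromatic ring for another at the same carbon, whereas here a ring leaves and a chain with a carbonyl and an amide hydrogen enters. For the measured compounds named here, the only guidance is that a change at this position moved the read-out by a modest amount once. The expected step is therefore a number 13 percentage points lower from compound 2 to compound 3 (beyond the scatter), without a clear direction, and with a wide range. Compound 3 is estimated at 50%, between 25% and 72% in this assay.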

Compound 3, a percentage reported as inhibition, in the whole organism at one dose (the size of the read-out at that dose, not a potency): 71%
The estimate for compound 3 lay 21 percentage points below the measured number, within the range that was stated.
By their numbers in this assay, from the lowest: compound 1; then compounds 2 and 3 (each within the scatter of the next).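

In this assay the aromatic carbon para to a large group turns out not to need a ring, since exchanging 3,5-dimethyl-1,2-oxazol-4-yl for the open (tert-butyl)carbamoyl gives a number 8 percentage points higher from compound 2 to compound 3 (within the scatter). The other comparison, a number 25 percentage points higher from compound 1 to compound 3 (beyond the scatter), shows that the same open group also clears the scatter against pyrimidin-5-yl, so among these three compounds only the pyrimidin-5-yl compound stands apart. Nothing on hand accounts for this outcome.

The compounds shown leave open whether the amide hydrogen, the carbonyl or the tert-butyl part matters for the number at this carbon. They also leave open how a carboxylic acid or a primary amine would read at the same place.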